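Furan to chlorophenyl on a penicillin-derived enone

The compounds below may be only part of what the source reports. "The series", "measured", "known", "first", "only" and "open" are said of these compounds alone.

Measured compounds:
compound 1 `CC1(C)S[C@@H]2/C(=C\C(=O)c3ccco3)C(=O)N2[C@H]1C(=O)OC(c1ccccc1)c1ccccc1` with 54300 nM
compound 2 `CC1(C)S[C@@H]2C/C(=C\C(=O)c3ccccc3)C(=O)N2[C@H]1C(=O)OC(c1ccccc1)c1ccccc1` with 73300 nM

The measurements come from a functional assay on OE19 cells (Homo sapiens) for cytotoxicity, read by MTT assay, with a stated time of 48 h; on this read-out higher numbers stand for weaker inhibition and lower numbers for stronger inhibition. In this assay compound 1 gives 54300 nM, and compound 2 gives 73300 nM; the two numbers lie within the scatter of each other, so neither can be placed ahead of the other. Compound 1 is simply the lower of the two numbers shown.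

Compound 3 `CC1(C)S[C@@H]2/C(=C\C(=O)c3ccc(Cl)cc3)C(=O)N2[C@H]1C(=O)OC(c1ccccc1)c1ccccc1` has not yet been measured. It differs from compound 1 in one place: 4-chlorophenyl in place of furan-2-yl on a carbonyl carbon. For the measured compounds named here, no measured pair shows this same change, so there is no step to lean on. Both measured compounds sit in the same weak region, and the change from compound 1 to compound 3 is expected to stay there as well, with a 1.2-fold lower number from compound 1 to compound 3 (0.08 log units; within the scatter) expected to fall within the usual scatter rather than beyond it. On that basis compound 3 is estimated at 45000 nM, with a range from 15000 nM to 130000 nM.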

Compound 3, half-maximal inhibitory concentration: 14600 nM
Estimate against measurement, compound 3: 3.1-fold (0.49 log units) above, and the stated range ends above it.
By their numbers in this assay, from the lowest: compound 3; then compounds 1 and 2 (each within the scatter of the next).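

In this assay, the group on the carbonyl carbon proves able to move the number: 4-chlorophenyl in place of furan-2-yl gives a 3.7-fold lower number from compound 1 to compound 3 (0.57 log units; beyond the scatter) and so yields the first difference in this set that can be read. The step is modest, yet it shows that this place on the shared core is not indifferent to what is attached there. Nothing shown gives a measured reason for the step.

The compounds shown leave open how much of the step belongs to the chlorine and how much to the six-membered ring in place of the five-membered one. They also leave open whether a 4-fluorophenyl, a 4-methoxyphenyl or a pyridine ring on the same carbonyl carbon would take the number lower still.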